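A few compounds are considered here, and "the series" means these few. Any claim that something is new, unique, unknown or untested is made for them only; others in the source may bear on it.

Compound 1 `CCCCNCCCC(=O)Nc1ccc(/C(N)=N/O)cc1` carries a saturated chain ending in a butylamino group on the shared core. In a functional assay on A549 cells (Homo sapiens) for antiproliferative activity, read by WST assay, with a stated time of 72 h (a lower number here means that less compound is needed, a higher number that more compound is needed for the effect), compound 1 gives > 1000000 nM, which is a limit of the assay and not a number. Compound 2 `CCCCCCNCCCCC(=O)Nc1ccc(/C(N)=N/O)cc1` is the longer-chain relative. In this assay compound 2 gives > 1000000 nM, again only a limit of the assay. The step that the two limits leave unreadable from compound 1 to compound 2 thus cannot be read in either direction. Both measured values sit at the limit of > 1000000 nM in this assay, at which 2 of the 2 values shown sit. Compound 3 `CCCCCCNCC(=O)Nc1ccc(/C(N)=N/O)cc1` rearranges the same atoms, so that (hexylamino in place of 2-(butylamino)ethyl on a saturated chain carbon bound to a carbonyl carbon). For the measured compounds named here, the only measured step that bears on this change is the one from compound 1 to compound 2, and its size is unreadable, so no direction can be drawn from it. With both measured compounds at the limit, compound 3 is expected to give 1000000 nM, in the range 300000 nM to 3000000 nM, most likely reported as a limit. The step expected from this estimate, a number no higher from compound 1 to compound 3 (the limit leaves the size open), is none beyond the scatter.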

Compound 3, half-maximal effective concentration: 658000 nM
Compound 3: middle estimate off by 1.5-fold (0.18 log units), on the high side; the measured number falls inside the stated range.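

Of the compounds shown, compound 3 alone gives a number in this assay and not a limit. Hexylamino in place of 2-(butylamino)ethyl on a saturated chain carbon bound to a carbonyl carbon therefore gives the first step with a readable direction, which is an at least 1.5-fold lower number from compound 1 to compound 3 (0.18 log units; that floor lies within the scatter) and which fixes only a floor on the size of the change, since the other value in that step is a limit. The number for compound 3 stands alone against the remaining values: the limit of > 1000000 nM in this assay, at which 2 of the 3 values shown sit.

The compounds shown leave open whether a step beyond the usual scatter can be reached at this carbon. They also leave open how butylamino, octylamino or a piperidine ring would read there in place of hexylamino.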